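Compound 3 to compound 4: replacing the benzamido group

A few compounds are considered here, and "the series" means these few. Any claim that something is new, unique, unknown or untested is made for them only; others in the source may bear on it.

In a functional assay on KBVIN cells (Homo sapiens) for antiproliferative activity, read by sulforhodamine B assay, with a stated time of 3 days (a lower number here means a stronger inhibitor of growth, a higher number a weaker inhibitor of growth), compound 3 (`O=C(Nc1cccc(Nc2ncc(F)c(Nc3ccc(F)cc3)n2)c1)c1ccccc1`) gives > 10000 nM, which is a limit. Compound 1 (`O=C(Nc1nccs1)c1cccc(Nc2ncc(F)c(Nc3ccc(F)cc3)n2)c1`) gives > 10000 nM, also a limit. Among the compounds with values here, compound 2 (`CN1CCC(C(=O)Nc2cccc(Nc3ncc(F)c(Nc4ccc(F)cc4)n3)c2)CC1`) gives 11900 nM, the only exact number here. The series is thus defined by the limit of > 10000 nM in this assay, at which 2 of the 3 values shown sit.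

Compound 4 (`O=C(NCCO)c1cccc(Nc2ncc(F)c(Nc3ccc(F)cc3)n2)c1`) carries (2-hydroxyethyl)carbamoyl in place of benzamido on an aromatic carbon.

Within the data shown here, three measured steps bear on this change: a step that the limit leaves unreadable from compound 1 to compound 2, a step that the two limits leave unreadable from compound 1 to compound 3 and a step that the limit leaves unreadable from compound 2 to compound 3. None has a readable size, so none gives a direction. The estimate rests on compound 2 at 11900 nM. The expected move is a step that the limit leaves unreadable from compound 3 to compound 4. Compound 4 is expected at 15000 nM, within an estimated range of 8000 nM to 30000 nM.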

Compound 4, concentration for 50% growth inhibition: 21400 nM
Compound 4: middle estimate off by 1.4-fold (0.15 log units), on the low side; low and high end bracket the measured number.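

Within the data shown here, the (2-hydroxyethyl)carbamoyl group gives this position a second exact number in this assay, and the only readable comparison is a 1.8-fold higher number from compound 2 to compound 4 (0.25 log units; within the scatter). It therefore does not separate this group from ((1-methylpiperidin-4-yl)carbonyl)amino. The steps to compound 4 from compound 1 and from compound 3 cannot be read, as each rests on a limit: the limit of > 10000 nM in this assay, at which 2 of the 4 values shown sit.

On these data alone, whether any group at this position gives a clearly lower number stays open. A longer chain ending in a carboxylic acid or a primary amine would bear on this.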